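Chloro to bromo: following compound 2 to compound 3

The compounds below may be only part of what the source reports. "The series", "measured", "known", "first", "only" and "open" are said of these compounds alone.

Compound 1 `Oc1cccc2ccc(Oc3ccccn3)nc12` gives > 30000 nM as a limit
Compound 2 `Oc1ccc(Cl)c2ccc(Oc3ccccn3)nc12` gives > 30000 nM as a limit

In a functional assay on PC-3 cells (Homo sapiens) for antiproliferative activity, read by MTT assay, with a stated time of 96 h (a higher number here means a weaker inhibitor of growth, a lower number a stronger inhibitor of growth), compound 2 gives > 30000 nM as a limit, not a number. Both measured compounds rest on the limit of > 30000 nM in this assay, at which 2 of the 2 values shown sit, and nothing finer. Compound 3 `Oc1ccc(Br)c2ccc(Oc3ccccn3)nc12` has bromo in place of chloro on an aromatic carbon. For the measured compounds named here, the only measured step is a step that the two limits leave unreadable from compound 1 to compound 2 and it offers no size to carry over. Going by the values given here, with that as the only guide, no step beyond the scatter is expected in this assay in either direction. The estimated step is a number no higher from compound 2 to compound 3 (the limit leaves the size open) for now. Compound 3 is estimated at 30000 nM with a range of 12000 nM to 60000 nM and may well return only a limit again.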

Compound 3, concentration for 50% growth inhibition: > 30000 nM
Compound 3 gave a limit, no number; the forecaster's own chance of this, stated with the estimate: 80%; the middle value lies on the limit itself.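

For the compounds shown here, compound 3 also gives a limit rather than a number, so no step between compound 1, compound 2 and compound 3 can be read in this assay: the limit of > 30000 nM in this assay, at which 3 of the 3 values shown sit. The compounds shown leave open whether hydrogen, chloro or bromo at this place on the shared core makes any difference.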